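The compounds below may be only part of what the source reports. "The series", "measured", "known", "first", "only" and "open" are said of these compounds alone.

Of the compounds shown here, two have been measured so far in a functional assay on HEK293 cells for antagonist activity at transient receptor potential cation channel subfamily V member 1 (Rattus norvegicus); on this read-out higher numbers stand for weaker inhibition and lower numbers for stronger inhibition. Compound 1, `O=C(Nc1ccc(Oc2ccccc2)cc1)N1CCN(c2ncccc2C(F)(F)F)CC1`, gives 258 nM in this assay. Compound 2, `CC(C)c1ccc(NC(=O)N2CCN(c3ncccc3[N+](=O)[O-])CC2)cc1`, gives 190 nM in this assay, which is the lower of the two numbers; the gap to compound 1 stays within the scatter of the method, so the two values read as equal within measurement noise, and neither compound can be called the stronger of the pair.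

Compound 3, `Cc1cccnc1N1CCN(C(=O)Nc2ccc(C(C)C)cc2)CC1`, has not been measured yet. It differs from compound 2 in one place: methyl in place of nitro on an aromatic carbon. For the measured compounds named here, no step between measured compounds in this assay involves this kind of change, so the expectation must rest on the two values shown and on the nature of the change alone. A methyl in place of a nitro at this position is expected to cost some inhibition, with a step in this assay of a 2.4-fold higher number from compound 2 to compound 3 (0.37 log units; beyond the scatter), a move toward weaker inhibition that should exceed the scatter but not by a wide margin. Compound 3 is therefore expected to give about 450 nM in this assay, with a likely range from 150 nM to 1400 nM.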

Compound 3, half-maximal inhibitory concentration: 25.3 nM
Estimate against measurement, compound 3: 18-fold (1.25 log units) above; the measured number lies below the stated range.
By their numbers in this assay, from the lowest: compound 3; then compounds 2 and 1 (each within the scatter of the next).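

In this assay, the change from 3-nitropyridin-2-yl to 3-methylpyridin-2-yl gives a 7.5-fold lower number from compound 2 to compound 3 (0.88 log units; beyond the scatter), a modest move toward stronger inhibition and the only step shown that lies beyond the scatter. It shows that inhibition responds to the group at this position, on the aromatic carbon two atoms from the ring nitrogen, something the first two values could not show, since those compounds differ in more than one place and read as equal. The nitro and its hydrogen-bond acceptors are also not required for inhibition at this level, as the methyl, which has no hydrogen-bond acceptors, gives the lower number with the rest of the compound unchanged.

Nothing shown here explains why the methyl outperforms the nitro. Going by these compounds, it remains open whether a chlorine, a methoxy or an ethyl at this position would keep, extend or lose this gain, and the trifluoromethyl of compound 1 offers no direct reading, as that compound differs from compound 3 in more than one place.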